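Swapping Fluoro for Hydroxy on a Shared Core

The compounds below may be only part of what the source reports. "The series", "measured", "known", "first", "only" and "open" are said of these compounds alone.

Compound 1 `COc1ccc(C(=O)/C=C/c2ccc(F)cc2)c2c1C=CC(C)(C)O2` carries a fluoro group on the outer aromatic ring of a shared core. In a functional assay on SW-620 cells (Homo sapiens) for antiproliferative activity, read by MTT assay, with a stated time of 24 h (on this read-out lower numbers stand for stronger inhibition and higher numbers for weaker inhibition), compound 1 gives > 10000 nM, which is a limit of the assay rather than a number. Two other compounds on the same core have been measured. Compound 2 `CCN(CC)c1ccc(/C=C/C(=O)c2ccc(OC)c3c2OC(C)(C)C=C3)cc1` has diethylamino in place of that fluoro, and in this assay compound 2 gives 670 nM. That exchange produced an at least 14-fold lower number from compound 1 to compound 2 (1.17 log units; beyond the scatter). Compound 3 `COc1ccc(/C=C/C(=O)c2ccc(OC)c3c2OC(C)(C)C=C3)cn1` instead has 6-methoxypyridin-3-yl in place of 4-fluorophenyl, and in this assay compound 3 gives > 10000 nM, again a limit. With limits at both ends, the change from compound 1 to compound 3 is a step that the two limits leave unreadable from compound 1 to compound 3.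

Compound 4 `COc1ccc(C(=O)/C=C/c2ccc(O)cc2)c2c1C=CC(C)(C)O2` differs from compound 1 by hydroxy in place of fluoro on an aromatic carbon. Within the data shown here, the one readable step from compound 1, the one to compound 2, shows that exchanging the fluoro at this aromatic carbon can lower the number strongly, but hydroxy is a different group from diethylamino, and compound 1 itself is known only as a limit, so the size of any step cannot be read from it. A modest lowering at most is expected. Compound 4 is estimated at 6000 nM, within 1500 nM to 20000 nM, which would be a step of an at least 1.6-fold lower number from compound 1 to compound 4 (0.22 log units; that floor lies within the scatter).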

Compound 4, half-maximal inhibitory concentration: > 10000 nM
Compound 4 ended at the assay's limit (the forecaster's own chance of this, stated with the estimate: 45%); at least 1.6-fold (0.22 log units) between middle value and limit.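

Hydroxy at this place, para to a large group, does not bring the number in this assay to a measurable value, so replacing fluoro here is not enough by itself to produce the activity seen with diethylamino. Putting hydroxy in place of diethylamino gives an at least 14-fold higher number from compound 2 to compound 4 (1.17 log units; beyond the scatter), which shows that the result at this carbon depends strongly on which group sits there. The steps that link compound 4 to compound 1 and compound 3 cannot be read, because both ends of each step are limits: the limit of > 10000 nM in this assay, at which 3 of the 4 values shown sit.

Going by these compounds, how compound 1 and compound 4 really compare stays open, so fluoro and hydroxy cannot be put in order on this core. On these data alone, it is also open what in diethylamino matters, and a plain amino group, a dimethylamino group or a methoxy group on the same carbon would help show whether the nitrogen or the two ethyl chains are needed.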